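The source may report more compounds than this note shows. Statements on the series, on what has been measured and on what is new or still open speak of the compounds shown alone.

Compound 1 `OC[C@H]1O[C@@H](n2cnc3c(NCc4ccccc4Cl)ncnc32)[C@H](O)[C@@H]1O` and compound 2 `Cc1ccc(CNc2ncnc3c2ncn3[C@@H]2O[C@H](CO)[C@@H](O)[C@H]2O)cc1` share one core and differ only in the group on a saturated chain carbon bound to a nitrogen on an aromatic ring. In a functional assay on K562 cells (Homo sapiens) for antiproliferative activity, with a stated time of 72 h (on this read-out lower numbers stand for stronger inhibition and higher numbers for weaker inhibition), compound 1 gives 64000 nM. For compound 2 this assay reports only a limit, > 166000 nM, as the limit of > 166000 nM in this assay, at which 1 of the 2 values shown sits, records. The step of an at least 2.5-fold higher number from compound 1 to compound 2 (0.41 log units; beyond the scatter) is the only measured one that bears on the next change. Compound 3 `OC[C@H]1O[C@@H](n2cnc3c(NCc4ccc(F)cc4F)ncnc32)[C@H](O)[C@@H]1O` carries 2,4-difluorophenyl in place of 4-methylphenyl on a saturated chain carbon bound to a nitrogen on an aromatic ring. Moving from the 4-methylphenyl back to a ring that, like 2-chlorophenyl, carries halogen, a modestly lower number is expected, an at least 1.8-fold lower number from compound 2 to compound 3 (0.26 log units; that floor lies within the scatter). Compound 3 is expected to give 90000 nM, between 30000 nM and 300000 nM.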

Compound 3, half-maximal inhibitory concentration: 9600 nM
For compound 3 the middle estimate is 9.4-fold (0.97 log units) above the measured one; the measured number lies below the stated range.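

Compared with the 4-methylphenyl, the 2,4-difluorophenyl brings an at least 17-fold lower number from compound 2 to compound 3 (1.23 log units; beyond the scatter), and compared with the 2-chlorophenyl it brings a 6.7-fold lower number from compound 1 to compound 3 (0.82 log units; beyond the scatter). Compound 3 is therefore the strongest of the three, and the two halogen-bearing rings do not score alike at this position. Compound 2 has only a limit, so the first of these steps gives a floor and not a true size: the limit of > 166000 nM in this assay, at which 1 of the 3 values shown sits.

The compounds shown leave open whether a single fluorine, as in 4-fluorophenyl or 2-fluorophenyl, would be enough. They also leave open how a ring carrying an amine or a carboxylic acid would behave here.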